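The compounds below may be only part of what the source reports. "The series", "measured", "known", "first", "only" and "open" are said of these compounds alone.

Working notes on the series at a single concentration.

For the measured compounds named here, compound 1 `COc1cc(-c2cc(/C=C/C(=O)c3ccc(Cl)c(Cl)c3)[nH]n2)cc(OC)c1OC` sits at the low end of the three numbers so far: in a functional assay on NCI-H23 cells (Homo sapiens) for cytotoxicity, read by sulforhodamine B assay, with a stated time of 48 h, tested at 0.1 uM (a lower number here means a stronger effect, a higher number a weaker effect of the compound at the concentration tested), compound 1 gives 92%. Compound 3 `COc1ccc(-c2cc(/C=C/C(=O)c3ccc(N)cc3)[nH]n2)cc1` is its nearest neighbour, and in this assay compound 3 gives 94%, a gap within the scatter. Compound 2 `COc1ccc(-c2cc(/C=C/C(=O)c3ccc(N)cc3)[nH]n2)cc1OC` is furthest away, and in this assay compound 2 gives 103%, a gap beyond the scatter. Going by the values given here, the only single-point step measured is a number 9 percentage points lower from compound 2 to compound 3 (within the scatter), a hydrogen in place of methoxy on the aryl attached to the core.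

Compound 4 `COc1ccc(C(=O)/C=C/c2cc(-c3cc(OC)c(OC)c(OC)c3)n[nH]2)cc1OC` differs from compound 1 on the other side of the molecule: 3,4-dimethoxyphenyl in place of 3,4-dichlorophenyl on a carbonyl carbon. Among the compounds with values here, no measured step touches the aryl on the carbonyl carbon, so the step from compound 2 to compound 3 bears on it only as a sign that swapping aromatic substituents elsewhere leaves the read-out within the scatter. Within the data shown here, all three values so far lie in a narrow band near full activity, which argues for a similar number. The expectation is therefore a step of a number 4 percentage points higher from compound 1 to compound 4 (within the scatter) that does not exceed the scatter. Compound 4 is estimated at 96%, in a range from 85% to 107%.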

Compound 4, a percentage reported as activity, at one concentration (the size of the read-out at that concentration, not a potency): 94%
For compound 4 the middle estimate is 2 percentage points above the measured one; the range from low to high includes it.
By their numbers in this assay, from the lowest: compounds 1, 3, 4 and 2 (each within the scatter of the next, the first and the last beyond it).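

For the compounds shown here, on a carbonyl carbon, 3,4-dimethoxyphenyl in place of 3,4-dichlorophenyl gives a number 2 percentage points higher from compound 1 to compound 4 (within the scatter) in this assay, the first measured step at this position. The entering group carries 2 hydrogen-bond acceptors and the leaving group carries 0, and this single-concentration read-out does not separate the two compounds, so at this position a chlorine-bearing and a methoxy-bearing aryl cannot be told apart at the concentration tested. No supporting data bear on why the change leaves the read-out within the scatter.

The compounds shown leave open whether any group on this aryl moves the read-out beyond the scatter, for instance a carboxylic acid or a nitrile in place of the two chlorines, or a saturated ring such as cyclohexyl in place of the whole aryl. Going by these compounds alone, it also remains open whether the same exchange gives a similar step when the aryl on the other side of the shared core is something other than the one present in compound 1 and compound 4.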